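Benzyl ether aryl swap on the pyrazole acid series

The source may hold more compounds than are shown below. What is called first, only, known or untested is meant among the compounds shown, and "the series" means these compounds.

Working notes on a small set of pyrazole and imidazole carboxylic acids bearing a bromophenyl methyl group and a benzyl ether, tested in a functional assay on CHO-K1 cells for antagonist activity at prostaglandin E2 receptor EP1 subtype (Homo sapiens), read by FLIPR; on this read-out lower numbers stand for stronger inhibition and higher numbers for weaker inhibition. Compound 1 `O=C(O)c1nn(Cc2cc(Br)ccc2OCc2ccccc2)cc1CO` gives in this assay a limit of the assay rather than a number, < 2000 nM. Compound 2 `O=C(O)c1cn(Cc2cc(Br)ccc2OCc2ccccc2)cn1` likewise returns only a limit of the assay, < 2000 nM. Going by the values given here, compound 3 `Cc1cc(C(=O)O)nn1Cc1cc(Br)ccc1OCc1ccc(F)cc1F` is the one member with a measured value, 2.63 nM. It is the only number shown; the two other entries sit at the limit of the assay (the limit of < 2000 nM in this assay, at which 2 of the 3 values shown sit), so no step between measured compounds can be drawn.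

The next compound, compound 4 `Cc1cc(C(=O)O)nn1Cc1cc(Br)ccc1OCc1cccc([N+](=O)[O-])c1`, differs from compound 3 in one place: 3-nitrophenyl in place of 2,4-difluorophenyl on a saturated chain carbon bound to an oxygen on an aromatic ring. The shared core and the bromophenyl methyl group are unchanged.

Among the compounds with values here, no measured step involves the benzyl ether aryl ring, so the direction of the change is open. A modest loss against compound 3 is expected, with the step from compound 3 to compound 4 estimated at a 3.0-fold higher number from compound 3 to compound 4 (0.48 log units; beyond the scatter), possibly not beyond the scatter. Compound 4 is therefore expected to give about 8 nM in this assay, within a range from 1.5 nM to 40 nM.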

Compound 4, inhibition constant: 339 nM
Estimate against measurement, compound 4: 42-fold (1.63 log units) below, outside the stated range (above it).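

In this assay the aryl ring of the benzyl ether now carries a measured step: 3-nitrophenyl in place of 2,4-difluorophenyl gives a 130-fold higher number from compound 3 to compound 4 (2.11 log units; beyond the scatter) and so this place, on a saturated chain carbon bound to an oxygen on an aromatic ring, is far from indifferent to the ring it holds. The shared core and the bromophenyl methyl group are the same in both compounds, so the whole step belongs to this one swap, although the swap removes the two fluorines and brings in the nitro group together, and the pair cannot separate these two parts. No measured property at hand accounts for the size of the step.

Compound 1 and compound 2 differ from compound 3 in more than one place, so steps to them cannot be read. Open, on these data alone, is whether the loss follows the arrival of the nitro group or the departure of the fluorines, which a plain phenyl, a monofluorophenyl, a methoxyphenyl or an aminophenyl ring at this place on the core of compound 3 would help to separate.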